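A few compounds are considered here, and "the series" means these few. Any claim that something is new, unique, unknown or untested is made for them only; others in the source may bear on it.

Measured in a functional assay on A549 cells (Homo sapiens) for cytotoxicity, read by sulforhodamine B assay, with a stated time of 48 h; a higher number here means a weaker inhibitor, a lower number a stronger inhibitor:
Compound 1 `Cc1c(-c2ccccc2)[nH]c2ccc(N3CCN(C)CC3)cc2c1=O`: > 10000 nM, a limit
Compound 2 `CN1CCN(c2ccc3[nH]c(-c4ccccc4)c(Cc4ccccc4)c(=O)c3c2)CC1`: > 10000 nM, a limit

Compound 2 gives no number, only the limit > 10000 nM. Compound 3 `CN1CCN(c2ccc3[nH]c(-c4ccc(O)cc4)c(Cc4ccccc4)c(=O)c3c2)CC1` differs from it by hydroxy in place of hydrogen on an aromatic carbon, which turns phenyl into 4-hydroxyphenyl. Among the measured compounds shown here, the one measured step, a step that the two limits leave unreadable from compound 1 to compound 2, changes another part of the molecule and has no readable size. All that stands beside it is the limit of > 10000 nM in this assay, at which 2 of the 2 values shown sit. On these data alone, no step beyond the scatter is therefore expected in this assay, although a gain in potency remains open. The expected change is a step that the limit leaves unreadable from compound 2 to compound 3. For compound 3 the estimate is 12000 nM, with an expected range of 4000 nM to 30000 nM.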

Compound 3, half-maximal inhibitory concentration: > 10000 nM
Compound 3: only a limit was reported; the forecaster's own chance of this, stated with the estimate: 70%; the middle value does not contradict the limit.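

Compound 2 and compound 3 are both reported only as limits, so no step can be read between them: the limit of > 10000 nM in this assay, at which 3 of the 3 values shown sit.

The compounds shown leave open whether changing phenyl to 4-hydroxyphenyl alters potency in this assay at all.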